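Varying the aryl group on a trimethoxyphenyl oxadiazoline core

The source may hold more compounds than are shown below. What is called first, only, known or untested is meant among the compounds shown, and "the series" means these compounds.

Measured compounds:
compound 1 `COc1cc(C2=NN(C(C)=O)C(c3c(Cl)cccc3Cl)O2)cc(OC)c1OC` gives 5.1%
compound 2 `COc1cc(C2=NN(C(C)=O)C(c3ccccc3C(F)(F)F)O2)cc(OC)c1OC` gives -11%

Both values come from a functional assay on PC-3 cells (Homo sapiens) for antiproliferative activity, read by MTT assay, tested at 1 uM; on this read-out lower numbers stand for a weaker effect and higher numbers for a stronger effect at the one concentration tested. Within the data shown here, compound 2 stands at the lower of the two numbers, with compound 1 as its only neighbour, and the one counted step, a number 16.1 percentage points lower from compound 1 to compound 2 (beyond the scatter), puts the gap between them beyond the scatter while both values stay close to zero effect.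

Compound 3 `COc1cc(C2=NN(C(C)=O)C(c3ccc(F)cc3)O2)cc(OC)c1OC` is the next member. Its change from compound 2 is 4-fluorophenyl in place of 2-(trifluoromethyl)phenyl on a saturated ring carbon. The measured step from compound 1 to compound 2 concerns a different exchange on the same saturated ring carbon, so it bears on compound 3 only loosely; it shows that swapping the aryl group there moved the read-out modestly. Among the measured compounds shown here, with no direct precedent for a 4-fluorophenyl at this position, the step to compound 3 is expected to be a number 11 percentage points higher from compound 2 to compound 3 (beyond the scatter), that is, nothing beyond the scatter. Compound 3 is therefore estimated at 0%, within -20% to 20%.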

Compound 3, a percentage reported as inhibition, at one concentration (the size of the read-out at that concentration, not a potency): 0%
For compound 3 middle estimate and measured number coincide at the digits printed; low and high end bracket the measured number.
By their numbers in this assay, from the lowest: compound 2; then compounds 3 and 1 (each within the scatter of the next).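

In this assay, 4-fluorophenyl in place of 2-(trifluoromethyl)phenyl on the saturated ring carbon gives a number 11 percentage points higher from compound 2 to compound 3 (beyond the scatter), the second step at this position to reach beyond the scatter. Exchanging 2,6-dichlorophenyl for 4-fluorophenyl gives a number 5.1 percentage points lower from compound 1 to compound 3 (within the scatter), so these two aryl groups are not separated here, and among the three compounds only the 2-(trifluoromethyl)phenyl group of compound 2 stands apart, with all three numbers still close to zero effect. Nothing available on these compounds accounts for that difference.

As far as these compounds go, it remains open whether an aryl group carrying an amine or a carboxylic acid on this ring carbon would give a clear effect at this concentration. Also open, from the compounds shown here alone, is how a longer acyl chain in place of the acetyl group would affect the read-out.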